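A Second Methoxy on the Sulfonamide Aryl Ring

The source may report more compounds than this note shows. Statements on the series, on what has been measured and on what is new or still open speak of the compounds shown alone.

Compound 1 `CN(C(=O)c1ccccc1)c1ccc2[nH]c(-c3n[nH]c4ccccc34)cc2n1` gives 4850 nM in a functional assay on HL-60 cells (Homo sapiens) for antiproliferative activity, read by MTT assay, with a stated time of 72 h; a lower number here means a stronger inhibitor, a higher number a weaker inhibitor. Compound 2 `COc1cccc(C(=O)N(C)c2ccc3[nH]c(-c4n[nH]c5ccccc45)cc3n2)c1` carries methoxy in place of hydrogen on an aromatic carbon and in this assay compound 2 gives 1420 nM, so that the step is a 3.4-fold lower number from compound 1 to compound 2 (0.53 log units; beyond the scatter). Compound 3 `COc1ccc(S(=O)(=O)N(C)c2ccc3[nH]c(-c4n[nH]c5ccccc45)cc3n2)cc1` gives 4340 nM in this assay; how the cores of compound 1 and compound 3 differ is not broken down here. Compound 4 `COc1ccc(S(=O)(=O)N(C)c2ccc3[nH]c(-c4n[nH]c5ccccc45)cc3n2)cc1OC` is compound 3 with methoxy in place of hydrogen on an aromatic carbon, the same kind of change as from compound 1 to compound 2, though here the entering group is ortho to a methoxy group, whereas in compound 2 it is only meta to a large group. Compound 4 is expected to show a 2.0-fold lower number from compound 3 to compound 4 (0.30 log units; within the scatter), somewhat smaller than the earlier step, because the change of the same kind gave a 3.4-fold lower number from compound 1 to compound 2 (0.53 log units; beyond the scatter) on a different core and with different surroundings. Compound 4 is estimated at 2200 nM, expected between 900 nM and 5500 nM.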

Compound 4, half-maximal inhibitory concentration: 6320 nM
For compound 4 the middle estimate is 2.9-fold (0.46 log units) below the measured one; measured number outside the range, above it.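

In this assay, methoxy in place of hydrogen on an aromatic carbon gives a 1.5-fold higher number from compound 3 to compound 4 (0.16 log units; within the scatter), so the gain seen on the core of compound 1 does not reappear on the core of compound 3. Set side by side, the two steps differ: the same change on two cores in this assay, a 3.4-fold lower number (0.53 log units; beyond the scatter) from compound 1 to compound 2 and a 1.5-fold higher number (0.16 log units; within the scatter) from compound 3 to compound 4, 5.0-fold (0.70 log units) apart, beyond the scatter of two such steps This shows that the size of the step did not carry over between these two cores, but with a single pair on each it does not show whether the core or the place of the entering group, ortho to a methoxy group in compound 4, accounts for the difference.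

From the compounds shown here alone, it remains open how a single methoxy in the place it holds in compound 2 would behave on the core of compound 3. Also open, going by these compounds, is whether an amine or a hydroxyl group in place of the entering methoxy would shift the number on either core.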